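The source may hold more compounds than are shown below. What is called first, only, known or untested is meant among the compounds shown, and "the series" means these compounds.

In a functional assay on COLO 205 cells (Homo sapiens) for inhibition, read by sulforhodamine B assay (a higher number here means a weaker inhibitor of growth, a lower number a stronger inhibitor of growth), compound 1 `Cc1ccc2[nH]c(-c3ccc(-c4ccc(-c5cccc(Cl)c5)cc4)cc3)nc2c1` gives 2780 nM and compound 2 `Oc1cccc2[nH]c(-c3ccc(-c4ccc(-c5ccc(C(F)(F)F)cc5)cc4)cc3)nc12` gives 3410 nM and these two values lie within the usual scatter of each other. Compound 3 `Cc1ccc2[nH]c(-c3ccc(-c4ccc(-c5ccc(C(F)(F)F)cc5)cc4)cc3)nc2c1` has 5-methyl-1H-benzimidazol-2-yl in place of 4-hydroxy-1H-benzimidazol-2-yl on an aromatic carbon and otherwise matches compound 2. Compound 1 carries the same 5-methyl-1H-benzimidazol-2-yl and gives 2780 nM so no step beyond the scatter is expected in this assay for this change. The estimated change is a 1.1-fold lower number from compound 2 to compound 3 (0.06 log units; within the scatter) and is expected to be small. For compound 3 the estimate is 3000 nM with 1200 nM to 7500 nM as the expected range.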

Compound 3, concentration for 50% growth inhibition: 30600 nM
The estimate for compound 3 lay 10-fold (1.01 log units) below the measured number; measured number above the stated range.
By their numbers in this assay, from the lowest: compounds 1 and 2 (each within the scatter of the next); then compound 3.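

In this assay both changed groups turn out to matter. With 4-(trifluoromethyl)phenyl held fixed, placing 5-methyl-1H-benzimidazol-2-yl in position of 4-hydroxy-1H-benzimidazol-2-yl weakens growth inhibition (a 9.0-fold higher number from compound 2 to compound 3 (0.95 log units; beyond the scatter)), and with that methyl group held fixed, replacing 3-chlorophenyl by 4-(trifluoromethyl)phenyl does too (an 11-fold higher number from compound 1 to compound 3 (1.04 log units; beyond the scatter)). The closeness of compound 1 and compound 2 therefore did not mean that these groups are interchangeable. No measurement here explains these steps. Still open, from the compounds shown here alone, is whether an amine or a methoxy group in place of the hydroxy would keep the lower number, and how 4-hydroxy-1H-benzimidazol-2-yl behaves alongside 3-chlorophenyl.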